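From Hydroxymethyl to 2-Hydroxyethyl: One Carbon Longer

The source may report more compounds than this note shows. Statements on the series, on what has been measured and on what is new or still open speak of the compounds shown alone.

Three compounds have been measured so far:

Compound 1, `O=C(/C=C/CN1CCCCC1)Nc1ccccc1`, gives 2.95 h.
Compound 2, `C=C(CO)C(=O)Nc1ccccc1`, gives only a limit of the assay, > 8.53 h.
Compound 3, `O=C(/C=C/C(F)(F)F)Nc1ccccc1`, gives 0.267 h.

These values come from an ADME assay for pharmacokinetics, read by LC-MS, in phosphate buffer, with a stated time of 120 min, at pH 7.4, tested at 1 uM, in the presence of a further agent that is not named here; a lower number here means that the compound disappears faster, a higher number that the compound lasts longer. Compound 2 stands at the top of what is shown, but its number is a limit rather than a measured value; it is the one compound at the limit of > 8.53 h in this assay, at which 1 of the 3 values shown sits. Compound 1 and compound 3 each give a measured half-life, and of the two, compound 3 disappears faster.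

Compound 4, `C=C(CCO)C(=O)Nc1ccccc1`, has not yet been measured. Its difference from compound 2 is hydroxymethyl in place of hydroxy on a saturated chain carbon bound to a double-bonded chain carbon. The change is small: the chain that carries the hydroxy group grows by one carbon, and nothing else moves.

Among the measured compounds shown here, no measured pair differs in just one place, so no measured step sets a scale. Given how little the structure changes, the step in this assay from compound 2 to compound 4 is expected to be none beyond the scatter, and that is what an at least 1.0-fold lower number from compound 2 to compound 4 (0.02 log units; that floor lies within the scatter) means. Compound 4 is therefore expected to give about 8 h, with a likely range from 3 h to 20 h.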

Compound 4, half-life: > 8.53 h
Compound 4 ended at the assay's limit; the forecaster's own chance of this, stated with the estimate: 55%; middle value at least 1.0-fold (0.02 log units) away from the limit.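

In this assay no step can be read from compound 2 to compound 4, because each of the two ends at a limit and not at a number: the limit of > 8.53 h in this assay, at which 2 of the 4 values shown sit.

Going by these compounds, how long compound 2 and compound 4 truly last, and whether going from hydroxymethyl to 2-hydroxyethyl changes the half-life at all, stays open.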